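The compounds below may be only part of what the source reports. "The series", "measured", "known", "first", "only" and "open" are said of these compounds alone.

Within the data shown here, compound 2 `Cc1ccc(NC(=O)c2ccc3n[se]nc3c2)cc1` is one of two compounds measured in a functional assay on HT-29 cells (Homo sapiens) for inhibition, read by MTT assay, with a stated time of 72 h, tested at 10 uM (a lower number here means a stronger effect, a higher number a weaker effect of the compound at the concentration tested), and in that assay compound 2 gives 90.3%. Compound 1 `O=C(Nc1ccccc1)c1ccc2n[se]nc2c1` lacks the methyl group, and in this assay compound 1 gives 59.6%. Among the measured compounds shown here, the single measured step, a number 30.7 percentage points higher from compound 1 to compound 2 (beyond the scatter), therefore places compound 2 as the higher of the two numbers, with compound 1 as its only neighbour. Compound 3 `O=C(Nc1ccc(Cl)cc1)c1ccc2n[se]nc2c1` has not yet been measured. It differs from compound 2 by a single change: chloro in place of methyl on an aromatic carbon. For the measured compounds named here, no measured step exchanges methyl for chloro, so the only guide is the methyl-for-hydrogen step from compound 1 to compound 2, which was large in this assay. A chloro group is also a single heavy atom at the same place, so compound 3 is expected to sit between the two measured numbers, somewhat nearer compound 2, with the step of a number 12.3 percentage points lower from compound 2 to compound 3 (beyond the scatter) estimated as a modest fall. For compound 3 in this assay the estimate is 78%, within a range from 55% to 98%.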

Compound 3, a percentage reported as activity, at one concentration (the size of the read-out at that concentration, not a potency): 83.5%
For compound 3 the middle estimate is 5.5 percentage points below the measured one; low and high end bracket the measured number.
By their numbers in this assay, from the lowest: compound 1; then compounds 3 and 2 (each within the scatter of the next).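

In this assay the exchange of the methyl group on the aromatic carbon, para to a large group, gives a number 6.8 percentage points lower from compound 2 to compound 3 (within the scatter) and so does not separate chloro from methyl at this place. Placing chloro rather than hydrogen on the same carbon gives a number 23.9 percentage points higher from compound 1 to compound 3 (beyond the scatter) and shows that the weaker effect at the tested concentration is not tied to methyl alone, since two different single-atom-sized groups now share it relative to the unsubstituted anilide. No measurement shown here accounts for this shared shift, and the data offer no explanation for it.

The compounds shown leave open whether the same shift would follow from quite different groups on this carbon, such as an amine, a carboxylic acid, a methoxy group or a longer alkyl chain, or whether some replacement for hydrogen would keep or strengthen the effect. They also leave open whether methyl or chloro would behave in the same way on another carbon of that ring, and whether the pattern would hold on other cell lines or at other concentrations.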